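The compounds below may be only part of what the source reports. "The series", "measured", "known", "first", "only" and "open" are said of these compounds alone.

Compound 2 `COCCOC(=O)/C(C#N)=C/c1c(-c2ccccc2)[nH]c2ccccc12` is one of two compounds examined in a functional assay on SK-MES-1 cells (Homo sapiens) for cytotoxicity, read by MTT assay, with a stated time of 96 h (a lower number here means that less compound is needed, a higher number that more compound is needed for the effect), where compound 2 gives 5000 nM. For the measured compounds named here, its only neighbour is compound 1 `N#C/C(=C\c1c(-c2ccccc2)[nH]c2ccccc12)C(=O)c1cccs1`, which in this assay gives 4000 nM; the two values lie within the scatter of each other, so compound 2 stands neither apart from nor clearly beyond compound 1. Compound 3 `N#C/C(=C\c1c(-c2ccccc2)[nH]c2ccccc12)C(=O)c1ccc(Cl)cc1` is the next compound in the series and has not yet been measured. The change from compound 2 to compound 3 is 4-chlorophenyl in place of 2-methoxyethoxy on a carbonyl carbon. Going by the values given here, the one step that bears on this change is the swap at the same carbonyl carbon: a 1.3-fold higher number from compound 1 to compound 2 (0.10 log units; within the scatter), a thiophen-2-yl ketone against a 2-methoxyethoxy ester, which left the number unchanged within the scatter. By the same token the return to an aryl ketone in compound 3 is expected to move the number little, a 1.3-fold lower number from compound 2 to compound 3 (0.10 log units; within the scatter). Compound 3 is therefore estimated at 4000 nM, with a range from 1500 nM to 11000 nM.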

Compound 3, half-maximal effective concentration: 19000 nM
Compound 3: middle estimate off by 4.8-fold (0.68 log units), on the low side; measured number above the stated range.
By their numbers in this assay, from the lowest: compounds 1 and 2 (each within the scatter of the next); then compound 3.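

In this assay the carbonyl carbon proves sensitive to what it carries, which the earlier pair had not shown: 4-chlorophenyl in place of 2-methoxyethoxy gives a 3.8-fold higher number from compound 2 to compound 3 (0.58 log units; beyond the scatter) and 4-chlorophenyl in place of thiophen-2-yl gives a 4.8-fold higher number from compound 1 to compound 3 (0.68 log units; beyond the scatter) as the second step. Compound 3 thus separates from both earlier compounds, while compound 1 and compound 2 remain within the scatter of each other. Being an aryl ketone does not by itself fix the number, since compound 1 and compound 3 are both aryl ketones and still differ beyond the scatter.

The compounds shown do not separate the chlorine from the phenyl ring, and they do not tell how an unsubstituted phenyl, an amine-bearing chain or a carboxylic acid would read at this carbonyl carbon. No supporting measurement is available to explain the higher number of compound 3.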